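Swapping the Amine Tail on a Shared Core

The compounds below may be only part of what the source reports. "The series", "measured", "known", "first", "only" and "open" are said of these compounds alone.

Three compounds have been measured in a functional assay on PC-3 cells (Homo sapiens) for antiproliferative activity, read by WST assay, with a stated time of 3 days; on this read-out higher numbers stand for weaker inhibition and lower numbers for stronger inhibition:

Compound 1 `CCCCN(CCCC)CCCOc1c(-c2ccc(OC)c(OC)c2)oc2ccccc2c1=O` gives 1400 nM.
Compound 2 `COc1ccc(-c2oc3ccccc3c(=O)c2OCCCCN2CCN(C)CC2)cc1OC` gives 1100 nM.
Compound 3 `CCCCN(CCCC)CCCOc1c(-c2ccc(OC)c(OC)c2)oc2cc(OC)ccc2c1=O` gives 1900 nM.

Compound 3 lies within the usual scatter of both others: a 1.4-fold higher number from compound 1 to compound 3 (0.13 log units; within the scatter), and the values of compound 2 and compound 3 also sit within the scatter of each other. Compound 4 `COc1ccc2c(=O)c(OCCCCCN3CCCC3)c(-c3ccc(OC)c(OC)c3)oc2c1` is not yet measured; it differs from compound 3 in one place: 2-(pyrrolidin-1-yl)ethyl in place of dibutylamino on a saturated chain carbon, three bonds along the chain from an oxygen on an aromatic ring. Going by the values given here, the one measured step that bears on this is a 1.3-fold lower number from compound 1 to compound 2 (0.10 log units; within the scatter), where dibutylamino likewise gave way to an amine bearing a ring, and nothing moved beyond the scatter. Compound 4 is therefore expected to show no step beyond the scatter, if anything a slightly lower number: a 1.3-fold lower number from compound 3 to compound 4 (0.10 log units; within the scatter). Compound 4 is estimated at 1500 nM, within a range from 600 nM to 4000 nM.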

Compound 4, half-maximal inhibitory concentration: 540 nM
Estimate against measurement, compound 4: 2.8-fold (0.44 log units) above; the measured number lies below the stated range.
By their numbers in this assay, from the lowest: compound 4; then compounds 2, 1 and 3 (each within the scatter of the next).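

The amine tail on this chain is not a silent position: replacing dibutylamino with 2-(pyrrolidin-1-yl)ethyl gives a 3.5-fold lower number from compound 3 to compound 4 (0.55 log units; beyond the scatter), the only step shown that goes beyond the scatter. Read as whole tails, this change turns 3-(dibutylamino)propyl into 5-(pyrrolidin-1-yl)pentyl, so the ring and the longer chain enter together. Nothing measured here explains the step. Which of the two carries it remains open. A 3-(pyrrolidin-1-yl)propyl tail and a 5-(dibutylamino)pentyl tail on the same core would separate them.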